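This account rests on a few compounds, and the source may have more. Where it says the series, first, only, none or still open, it means among the compounds named here.

Measured compounds:
Compound 1 `Cc1cc(C)n(-c2nc(-c3ccc(F)cc3)cc(=O)[nH]2)n1` gives 4000 nM in an ADME assay on CHO cells (Cricetulus griseus) for cytotoxicity, read by MTT assay; on this read-out higher numbers stand for weaker inhibition and lower numbers for stronger inhibition.
Compound 2 `Cc1cc(C)n(-c2nc(-c3ccc(NS(C)(=O)=O)cc3)cc(=O)[nH]2)n1` is known in this assay only as a limit, > 50000 nM.

Within the data shown here, the one measured step, an at least 12-fold higher number from compound 1 to compound 2 (1.09 log units; beyond the scatter), ends at the limit of > 50000 nM in this assay, at which 1 of the 2 values shown sits, so its true size is open; it is at least large, in the direction of weaker inhibition. Compound 2 therefore stands at the weak end of what has been measured, without a number of its own.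

Compound 3 `CNC(=O)c1ccc(-c2cc(=O)[nH]c(-n3nc(C)cc3C)n2)cc1` carries the change (methylcarbamoyl in place of methanesulfonamido on an aromatic carbon). Among the measured compounds shown here, no measured step covers this exchange. For the measured compounds named here, the only comparison at hand is the step from compound 1 to compound 2, which shows that a polar, donor-bearing group at this position goes with weak inhibition; methylcarbamoyl also brings one hydrogen-bond donor and one hydrogen-bond acceptor, though with one heavy atom fewer and no sulfur. On that basis the step of an at least 1.2-fold lower number from compound 2 to compound 3 (0.09 log units; that floor lies within the scatter) is expected to be small and may well not be resolved, since compound 2 is itself at the limit. Compound 3 is expected to give about 40000 nM, within 12000 nM to 150000 nM.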

Compound 3, half-maximal inhibitory concentration: > 50000 nM
Compound 3: only a limit was reported; the forecaster's own chance of this, stated with the estimate: 50%; at least 1.2-fold (0.09 log units) between middle value and limit.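

In this assay, methylcarbamoyl in place of fluoro on this aromatic carbon gives an at least 12-fold higher number from compound 1 to compound 3 (1.09 log units; beyond the scatter), so the large move toward weaker inhibition no longer rests on methanesulfonamido alone. Compound 3 is known only as a limit, > 50000 nM, and this is not a number. Compound 2 and compound 3 both end at the limit, so the step between them cannot be read and the two replacement groups cannot be ordered: the limit of > 50000 nM in this assay, at which 2 of the 3 values shown sit.

Among these compounds, compound 1 remains the only compound here with a number, 4000 nM, so the true size of the move away from fluoro stays open for both replacement groups. Also open, going by these compounds, is whether other groups on the same aromatic carbon, such as an amine, a carboxylic acid or a nitrile, would stay near compound 1 or would also reach the limit, which would show how widely the change away from fluoro carries over.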